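Fluoro in Place of Hydrogen: What to Expect of Compound 4

A few compounds are considered here, and "the series" means these few. Any claim that something is new, unique, unknown or untested is made for them only; others in the source may bear on it.

Measured compounds:
compound 1 `O=Cc1cn(Cc2ccc(Cl)cc2)c2cc(F)ccc12` — 120 nM
compound 2 `OCc1cc2cc(F)ccc2n1Cc1ccc(Cl)cc1` — 11500 nM
compound 3 `OCc1cn(Cc2ccccc2)c2ccccc12` — 112 nM

In a functional assay on NCI-H460 cells (Homo sapiens) for cytotoxicity, read by sulforhodamine B assay, with a stated time of 3 days (a higher number here means a weaker inhibitor, a lower number a stronger inhibitor), compound 3 holds the lowest of the three numbers shown, though compound 1 sits within the usual scatter of it, so no order between those two can be drawn. Compound 2 lies far higher, beyond the scatter. Compound 4 `OCc1cn(Cc2cccc(F)c2)c2ccccc12` differs from compound 3 by fluoro in place of hydrogen on an aromatic carbon. For the measured compounds named here, no pair among the measured compounds isolates such a change, so nothing here shows how it acts. The step from compound 3 is therefore expected to be small, a 1.0-fold lower number from compound 3 to compound 4 (0.01 log units; within the scatter), with no direction beyond the scatter. Compound 4 is estimated at 110 nM, within 40 nM to 320 nM.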

Compound 4, half-maximal inhibitory concentration: 40 nM
The estimate for compound 4 lay 2.8-fold (0.44 log units) above the measured number, and the stated range covers the measured number.
By their numbers in this assay, from the lowest: compound 4; then compounds 3 and 1 (each within the scatter of the next); then compound 2.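

In this assay, for the compounds shown here, fluoro in place of hydrogen on an aromatic carbon, meta to a large group, gives the first single change that can be read, with a 2.8-fold lower number from compound 3 to compound 4 (0.45 log units; beyond the scatter) as a modest step beyond the scatter. This place on the six-membered aromatic ring of carbon only therefore accepts fluoro, and the number falls rather than rises. Nothing at hand accounts for the step. As far as these compounds go, whether a methoxy group or an amine at this place would move the number the same way remains open. So does the effect of fluoro elsewhere on this ring.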